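A chlorinated sulfonamide tested where every value is a limit

The compounds below may be only part of what the source reports. "The series", "measured", "known", "first", "only" and "open" are said of these compounds alone.

Compound 1, `O=S(=O)(Nc1ccc(-c2nc3ccccc3o2)cc1)c1ccccc1O`, carries a 2-hydroxyphenyl group on its sulfonyl sulfur. In an assay on isolated protein for inhibition of malate dehydrogenase, mitochondrial (Sus scrofa), with stated times of 45 min and 30 min (on this read-out higher numbers stand for weaker inhibition and lower numbers for stronger inhibition), compound 1 gives only a limit, > 63000 nM. Compound 2, `Cc1cccc(S(=O)(=O)Nc2ccc3oc(-c4ccccc4)nc3c2)c1`, in this assay also reaches only a limit, > 63000 nM. Compound 3, `O=S(=O)(Nc1ccc(-c2nc3ccccc3o2)cc1)c1ccccc1C(F)(F)F`, likewise shows only a limit, > 63000 nM. The step that the two limits leave unreadable from compound 1 to compound 3 therefore cannot be read, as the limit of > 63000 nM in this assay, at which 3 of the 3 values shown sit, shows: every measured value sits at the same boundary, so nothing can be said about whether one compound inhibits more strongly than another.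

Compound 4, `O=S(=O)(Nc1ccc(-c2nc3ccccc3o2)cc1)c1ccc(Cl)cc1`, is not yet measured. It differs from compound 1 in one place: 4-chlorophenyl in place of 2-hydroxyphenyl on a sulfonyl sulfur. Going by the values given here, no measured step bears on this change with a readable size; the single step recorded between measured compounds is itself unreadable. Given (the limit of > 63000 nM in this assay, at which 3 of the 3 values shown sit), compound 4 is expected to stay at that boundary too, with an estimated value of 80000 nM and a range from 20000 nM to 300000 nM. The expected step that the limit leaves unreadable from compound 1 to compound 4 is thus no change beyond the scatter.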

Compound 4, half-maximal inhibitory concentration: > 63000 nM
Compound 4: no number, only a limit; the forecaster's own chance of this, stated with the estimate: 80%; the middle value is on the limit's open side.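

In this assay compound 4 gives > 63000 nM as a limit only. Compound 1 also gives only a limit, so the step between compound 1 and compound 4 cannot be read: the limit of > 63000 nM in this assay, at which 4 of the 4 values shown sit. From the compounds shown here alone, whether 4-chlorophenyl and 2-hydroxyphenyl differ in their effect on inhibition remains open.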